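A few compounds are considered here, and "the series" means these few. Any claim that something is new, unique, unknown or untested is made for them only; others in the source may bear on it.

Compound 1 `CCOc1ccc(NC(=O)C2Cc3cc(OC)c(OC)cc3C2=O)cc1` gives 48.2 ug/mL
Compound 2 `CCc1cccc(NC(=O)C2Cc3cc(OC)c(OC)cc3C2=O)c1` gives 64.1 ug/mL

Both values come from a physicochemical assay, with a stated time of 30 min (on this read-out lower numbers stand for stronger inhibition and higher numbers for weaker inhibition), and lie within the usual scatter of each other, so compound 2 cannot be ranked against compound 1. Compound 3 `COc1cc2c(cc1OC)C(=O)C(C(=O)Nc1ccccc1F)C2` keeps the shared core but carries 2-fluorophenyl in place of 3-ethylphenyl on an amide-type nitrogen. Within the data shown here, no measured pair shows what such a swap does, so the expectation rests on compound 2 at 64.1 ug/mL and no shift beyond the scatter, in either direction, is expected. The estimated change is small (a 1.2-fold lower number from compound 2 to compound 3 (0.07 log units; within the scatter)). For compound 3 the expected value is 55 ug/mL (estimated range 25 ug/mL to 120 ug/mL).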

Compound 3, half-maximal inhibitory concentration: 75.7 ug/mL
Beside the measured number, compound 3's estimate is 1.4-fold (0.14 log units) below it; measured number inside the range.
By their numbers in this assay, from the lowest: compounds 1, 2 and 3 (each within the scatter of the next).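

In this assay, among these compounds, the swap to 2-fluorophenyl from 3-ethylphenyl on the amide-type nitrogen gives a 1.2-fold higher number from compound 2 to compound 3 (0.07 log units; within the scatter) and is the first single-place comparison here. At this position, then, this exchange of one substituted phenyl ring for another produces no change that can be told from the scatter. No measurement shown explains this result.

Going by these compounds, it remains open whether an amine or a carboxylic acid on this phenyl ring would move the number beyond the scatter. The same question applies to a longer chain in place of the ethyl group.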